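The source may report more compounds than this note shows. Statements on the series, on what has been measured and on what is new or still open speak of the compounds shown alone.

Measured compounds:
- compound 1, `CC(=O)CCCON1C(=O)[C@@H](NC(=O)OCCCCC2CCCCC2)[C@@H]1C`: 75 nM
- compound 2, `C[C@H]1[C@H](NC(=O)OCCCCC2CCCCC2)C(=O)N1OCCCCC1CCCCC1`: 3470 nM
- compound 3, `C[C@H]1[C@H](NC(=O)OCCCCC2CCCCC2)C(=O)N1OCCCCc1ccccc1`: 1240 nM

In an assay on HEK293 cells for inhibition of N-acylethanolamine-hydrolyzing acid amidase (Homo sapiens), read by fluorescence, with stated times of 10 min and 50 min (a lower number here means a stronger inhibitor, a higher number a weaker inhibitor), compound 3 stands second highest of the three numbers. Its nearest neighbour is compound 2, with a 2.8-fold lower number from compound 2 to compound 3 (0.45 log units; beyond the scatter) separating them; its furthest is compound 1, with a 17-fold higher number from compound 1 to compound 3 (1.22 log units; beyond the scatter) between them.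

Compound 4, `C[C@H]1[C@H](NC(=O)OCCCCC2CCCCC2)C(=O)N1Oc1ccc([N+](=O)[O-])cc1`, has not yet been measured. It differs from compound 3 at the group on the oxygen attached to the ring nitrogen: 4-nitrophenyl in place of 4-phenylbutyl on an oxygen.

The measured steps all alter what sits on that same oxygen chain. The exchange of one ring for another, a 2.8-fold lower number from compound 2 to compound 3 (0.45 log units; beyond the scatter), was modest, whereas the exchange of acetyl for a ring-bearing chain, a 46-fold higher number from compound 1 to compound 2 (1.67 log units; beyond the scatter) and a 17-fold higher number from compound 1 to compound 3 (1.22 log units; beyond the scatter), was large. None of them places an aromatic ring directly on the oxygen or adds a nitro group, so the direction of the step to compound 4 is uncertain. Compound 4 is expected to give 600 nM, within 100 nM to 4000 nM, corresponding to an estimated 2.1-fold lower number from compound 3 to compound 4 (0.32 log units; beyond the scatter).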

Compound 4, half-maximal inhibitory concentration: 17 nM
Compound 4: middle estimate off by 35-fold (1.55 log units), on the high side; measured number below the stated range.
By their numbers in this assay, from the lowest: compound 4; then compound 1; then compound 3; then compound 2.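

In this assay, putting 4-nitrophenyl on the oxygen attached to the ring nitrogen gives a 73-fold lower number from compound 3 to compound 4 (1.86 log units; beyond the scatter) and a 200-fold lower number from compound 2 to compound 4 (2.31 log units; beyond the scatter), both large, so this position can lower the number far more than swapping the ring at the end of a butyl chain did. It also gives a 4.4-fold lower number from compound 1 to compound 4 (0.64 log units; beyond the scatter), a modest step that places compound 4 lowest of the four and shows that a group with a ring on this oxygen need not lose out to the 3-acetylpropyl chain. Nothing available here accounts for these steps.

The change from 4-phenylbutyl to 4-nitrophenyl both removes the chain and adds the nitro group, and these compounds leave open how much each contributes. A plain phenyl on this oxygen, or a 4-aminophenyl, would help to separate the two.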